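The source may hold more compounds than are shown below. What is called first, only, known or untested is meant among the compounds shown, and "the series" means these compounds.

Measured in a functional assay on MDA-MB-231 cells (Homo sapiens) for antiproliferative activity, read by MTT assay, with a stated time of 48 h; a lower number here means a stronger inhibitor, a higher number a weaker inhibitor:
- compound 1 `C=CS(=O)(=O)N1CCN(c2ncnc3sc(-c4ccc(C#N)cc4)cc23)CC1`: 8050 nM
- compound 2 `C=CS(=O)(=O)N1CCN(c2ncnc3sc(-c4cccc5ncccc45)cc23)CC1`: 21000 nM
- compound 3 `C=CS(=O)(=O)N1CCN(c2ncnc3sc(-c4ccc(OC)nc4)cc23)CC1`: 9270 nM

Compound 3 sits level with compound 1, as a 1.2-fold higher number from compound 1 to compound 3 (0.06 log units; within the scatter) shows. It stands clear of compound 2 only, with a 2.3-fold lower number from compound 2 to compound 3 (0.36 log units; beyond the scatter).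

Next is compound 4 `C=CS(=O)(=O)N1CCN(c2ncnc3sc(-c4cc(Br)cnc4F)cc23)CC1`, with 5-bromo-2-fluoropyridin-3-yl in place of 6-methoxypyridin-3-yl on the aromatic carbon next to the ring sulfur (5-bromo-2-fluoropyridin-3-yl in place of 6-methoxypyridin-3-yl on an aromatic carbon).

All three measured steps are exchanges at this same carbon. The two modest ones both involve the quinolin-5-yl group of compound 2: a 2.6-fold higher number from compound 1 to compound 2 (0.42 log units; beyond the scatter) and a 2.3-fold lower number from compound 2 to compound 3 (0.36 log units; beyond the scatter). The exchange between the groups with one six-membered aromatic ring gave only a 1.2-fold higher number from compound 1 to compound 3 (0.06 log units; within the scatter), and the entering group also has one such ring. Among the measured compounds shown here, no measured compound carries bromine or fluorine, so the data give no direction for this change. The closest guide is therefore the step between compound 1 and compound 3, with the modest steps as the outer bound on what is likely.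

The expected change is a 1.2-fold lower number from compound 3 to compound 4 (0.06 log units; within the scatter), so no step beyond the scatter is anticipated, though a modest one either way remains possible. The estimate for compound 4 is 8000 nM. The expected range runs from 3000 nM to 21000 nM.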

Compound 4, half-maximal inhibitory concentration: 24100 nM
Compound 4: middle estimate off by 3.0-fold (0.48 log units), on the low side; the whole stated range lies below it.
By their numbers in this assay, from the lowest: compounds 1 and 3 (each within the scatter of the next); then compounds 2 and 4 (each within the scatter of the next).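

The exchange at the carbon next to the ring sulfur shows that one six-membered aromatic ring does not by itself hold the number at the level of compound 1 and compound 3, with a 2.6-fold higher number from compound 3 to compound 4 (0.41 log units; beyond the scatter) and a 3.0-fold higher number from compound 1 to compound 4 (0.48 log units; beyond the scatter) as the two modest steps, even though 5-bromo-2-fluoropyridin-3-yl and 6-methoxypyridin-3-yl have the same heavy-atom count. Compound 4 instead stands level with the quinolin-5-yl compound, with a 1.1-fold higher number from compound 2 to compound 4 (0.06 log units; within the scatter) as the step, so the higher numbers at this carbon no longer belong to the quinolin-5-yl group alone. Single-ring groups at this position now span a modest range in this assay and no longer sit only within the scatter, as the pair of compound 1 and compound 3 alone suggested.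

The compounds shown do not separate the bromine from the fluorine of the entering group, and how an amine or a carboxylic acid on the pyridine ring would read at this carbon remains open. No measurement at hand offers a reason for these steps.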